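Swapping the aryl group on the triazole: from dimethyl to chloro-methyl

The source may report more compounds than this note shows. Statements on the series, on what has been measured and on what is new or still open speak of the compounds shown alone.

Compound 1 `Cc1ccc(-n2nncc2CN2C(=O)C3(C(C#N)=C(N)Oc4c3c3nc5ccccc5nc3c3ccccc43)c3ccccc32)cc1C`: > 50000 nM
Compound 2 `Cc1cc(C)cc(-n2nncc2CN2C(=O)C3(C(C#N)=C(N)Oc4c3c3nc5ccccc5nc3c3ccccc43)c3ccccc32)c1`: > 50000 nM

Of the compounds shown here, two on a shared core have been tested in a functional assay on HCT-116 cells (Homo sapiens) for antiproliferative activity, read by MTT assay, with a stated time of 48 h; a higher number here means a weaker inhibitor, a lower number a stronger inhibitor. Compound 1 gives only a limit of the assay there, > 50000 nM. Compound 2 likewise gives only a limit, > 50000 nM. Within the data shown here, the single measured step, a step that the two limits leave unreadable from compound 1 to compound 2, cannot be sized, since both ends rest on (the limit of > 50000 nM in this assay, at which 2 of the 2 values shown sit). So compound 2 stands at the limit, with no number of its own.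

Compound 3 `Cc1ccc(-n2nncc2CN2C(=O)C3(C(C#N)=C(N)Oc4c3c3nc5ccccc5nc3c3ccccc43)c3ccccc32)cc1Cl` differs from compound 2 in one place: 3-chloro-4-methylphenyl in place of 3,5-dimethylphenyl on an aromatic nitrogen. Among the measured compounds shown here, the only step that bears on this change is a step that the two limits leave unreadable from compound 1 to compound 2, which shows that trading one dimethylphenyl for another left both compounds at the limit. Nothing measured suggests a change in this assay beyond the scatter, and the most likely outcome is that compound 3 also reports only a limit. The expected step that the limit leaves unreadable from compound 2 to compound 3 is therefore none beyond the scatter. Compound 3 is estimated at 70000 nM, in the range 25000 nM to 200000 nM.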

Compound 3, half-maximal inhibitory concentration: > 50000 nM
Compound 3 was reported as a limit (the forecaster's own chance of this, stated with the estimate: 85%); the middle value is on the limit's open side.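

Compound 3 gives > 50000 nM in this assay and this is only a limit of the assay. Its steps from compound 1 and compound 2 therefore cannot be read, because all three compounds rest on one limit: the limit of > 50000 nM in this assay, at which 3 of the 3 values shown sit. The compounds shown leave open whether any aryl group at this place on the shared core would give a measurable value in this assay and how large a step between such groups would be.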